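The source may hold more compounds than are shown below. What is called first, only, known or untested is meant among the compounds shown, and "the series" means these compounds.

Compound 1 `O=C(Nc1ccccc1)C1CCN(C/C=C/c2ccccc2)CC1`: 57900 nM
Compound 2 `O=C(Nc1cccc(F)c1)C1CCN(C/C=C/c2ccccc2)CC1`: 23300 nM
Compound 3 `O=C(Nc1cccc(Cl)c1)C1CCN(C/C=C/c2ccccc2)CC1`: 11300 nM
Compound 4 `O=C(NCc1ccccc1)C1CCN(C/C=C/c2ccccc2)CC1`: not yet measured

All of these values come from a functional assay on MGC-803 cells (Homo sapiens) for inhibition, read by MTT assay, with a stated time of 72 h; on this read-out lower numbers stand for stronger inhibition and higher numbers for weaker inhibition. Compound 3 has the lowest number of the three measured compounds, and its gaps to the other two lie beyond the scatter. The next step makes one structural change: benzyl in place of 3-chlorophenyl on an amide-type nitrogen.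

Among the measured compounds shown here, no measured step makes this exchange, so the evidence is indirect. Adding a halogen to the ring lowered the number in both cases: a 2.5-fold lower number from compound 1 to compound 2 (0.40 log units; beyond the scatter) and a 5.1-fold lower number from compound 1 to compound 3 (0.71 log units; beyond the scatter). Compound 4 has no chloro, so this modest gain is expected to be lost, although the data do not show what the benzyl group itself does. A modest step towards a higher number therefore seems likely. The expected step is a 3.5-fold higher number from compound 3 to compound 4 (0.55 log units; beyond the scatter). The estimated value for compound 4 is 40000 nM, with an expected range from 12000 nM to 120000 nM.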

Compound 4, half-maximal inhibitory concentration: > 100000 nM
Compound 4: only a limit was reported; the forecaster's own chance of this, stated with the estimate: 15%; at least 2.5-fold (0.39 log units) between middle value and limit.
By their numbers in this assay, from the lowest: compound 3; then compound 2; then compound 1. At a limit, above all of these: compound 4.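

In this assay, compound 4 gives only a limit, not a number: the limit of > 100000 nM in this assay, at which 1 of the 4 values shown sits. Earlier changes only placed a halogen on the phenyl ring, whereas this change on the amide-type nitrogen replaces the ring group itself, and the halogenated compounds clearly keep the lower numbers: an at least 8.8-fold higher number from compound 3 to compound 4 (0.94 log units; beyond the scatter), and an at least 4.2-fold higher number from compound 2 to compound 4 (0.63 log units; beyond the scatter). Against the plain phenyl group the comparison is weaker, an at least 1.7-fold higher number from compound 1 to compound 4 (0.23 log units; that floor lies within the scatter), so benzyl itself cannot be said to do worse than phenyl.

The compounds shown leave open whether 3-chlorobenzyl on this nitrogen would lower the number, as chloro did on the phenyl ring. They also leave open how a longer chain, such as 2-phenylethyl, would behave at this position.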